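The compounds below may be only part of what the source reports. "The series", "measured", "known", "first", "only" and "open" are said of these compounds alone.

Compound 3 `COc1ccc(NC2=CC(=O)c3nc4n(c3C2=O)[C@H]2OC[C@@H](O)[C@H]2OC4)cc1` gives 5420 nM in a functional assay on MCF7 cells (Homo sapiens) for inhibition, read by sulforhodamine B assay (a lower number here means a stronger inhibitor, a higher number a weaker inhibitor), the higher of the two plain numbers here. Compound 2 `CCCc1ccc(NC2=CC(=O)c3nc4n(c3C2=O)[C@H]2OC[C@@H](O)[C@H]2OC4)cc1` gives 4660 nM, and the step of a 1.2-fold higher number from compound 2 to compound 3 (0.07 log units; within the scatter) lies within the scatter. Compound 1 `COc1cccc(NC2=CC(=O)c3nc4n(c3C2=O)[C@H]2OC[C@@H](O)[C@H]2OC4)c1` shows only a limit of the assay, > 4000 nM, so the steps from compound 1 cannot be read in size. Compound 4 `O=C1C=C(N2CCCC2)C(=O)c2c1nc1n2[C@H]2OC[C@@H](O)[C@H]2OC1` differs from compound 3 by pyrrolidin-1-yl in place of (4-methoxyphenyl)amino on a double-bonded ring carbon. Among the measured compounds shown here, none of the measured steps swaps the whole aromatic amine for a saturated ring amine; the one readable step only changes a substituent on that aromatic ring and stays within the scatter. The expected step from compound 3 is therefore a 1.3-fold higher number from compound 3 to compound 4 (0.11 log units; within the scatter). Compound 4 is estimated at 7000 nM, within 2500 nM to 20000 nM.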

Compound 4, half-maximal inhibitory concentration: > 16000 nM
Compound 4: no number, only a limit (the forecaster's own chance of this, stated with the estimate: 40%); middle value at least 2.2-fold (0.35 log units) away from the limit.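

In this assay, among the compounds shown here, replacing the aromatic amine on this double-bonded ring carbon with pyrrolidin-1-yl gives an at least 2.9-fold higher number from compound 3 to compound 4 (0.47 log units; beyond the scatter) and is the first readable step here beyond the scatter. The earlier readable step changed only a substituent on the aromatic ring and stayed within the scatter, so exchanging the whole group matters more in these compounds. Compound 4 gives no number, only a limit of the assay: the limit of > 16000 nM in this assay, at which 1 of the 4 values shown sits.

As far as these compounds go, the full size of this step remains unknown, and the steps from compound 1 cannot be read. From the compounds shown here alone, it remains open whether a benzylamine or morpholine at this position would behave more like the aromatic amines or like pyrrolidin-1-yl.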